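Switching the acid side chain for sec-butyl

This account rests on a few compounds, and the source may have more. Where it says the series, first, only, none or still open, it means among the compounds named here.

Measured so far:
compound 1 `CC(C)C[C@H](NC(=O)CN(c1nc(Cl)nc2[nH]cnc12)C1CC1)C(=O)OCc1ccccc1`: 15.2%
compound 2 `O=C(O)C[C@H](NC(=O)CN(c1nc(Cl)nc2[nH]cnc12)C1CC1)C(=O)O`: 25.1%

Two compounds share a core and differ in their amino-acid part. In a functional assay on the whole organism (Tail, strain ICR) with Mus musculus as the target, in the tail flick test, with a stated time of 90 min, at a dose of 25 umol/kg by the oral route (a lower number here means a weaker effect, a higher number a stronger effect of the compound at the dose given), compound 1 gives 15.2%, and compound 2 gives 25.1%. Compound 2 shows the higher of the two numbers, but the gap to compound 1 lies within the usual scatter, so the two cannot be ranked against each other on these data.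

Compound 3 `CC[C@H](C)[C@H](NC(=O)CN(c1nc(Cl)nc2[nH]cnc12)C1CC1)C(=O)O` is not yet measured. Its change from compound 2 is sec-butyl in place of carboxymethyl on a saturated chain carbon bound to an amide-type nitrogen and a carbonyl carbon. For the measured compounds named here, with no measured step of the same kind available, the expectation rests only on the two values above, which sit close together despite a larger structural difference between compound 1 and compound 2. The step from compound 2 to compound 3 is therefore expected to be small, a number 4.1 percentage points lower from compound 2 to compound 3 (within the scatter), most likely not beyond the scatter, with a slight lean downward. In this assay compound 3 is expected to give 21%, with a range from 8% to 38%.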

Compound 3, a percentage reported as activity, at one dose (the size of the read-out at that dose, not a potency): 27.4%
For compound 3 the middle estimate is 6.4 percentage points below the measured one, within the range that was stated.
By their numbers in this assay, from the lowest: compounds 1, 2 and 3 (each within the scatter of the next, the first and the last beyond it).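

In this assay, for the compounds shown here, the swap of carboxymethyl for sec-butyl on the saturated chain carbon bound to an amide-type nitrogen and a carbonyl carbon gives a number 2.3 percentage points higher from compound 2 to compound 3 (within the scatter) and is the first comparison here in which two compounds differ in one place only. At this position, a side chain with a carboxylic acid, which counts one hydrogen-bond donor and one hydrogen-bond acceptor, can therefore give way to an all-carbon chain with the same number of heavy atoms without a difference that can be told apart from ordinary repeat scatter at this dose. Nothing available explains why the two compounds read alike.

On these data alone, whether this position tolerates other side chains remains open, for example a primary amine, a benzyl group or a longer unbranched carbon chain. A reading at one dose and one time point is also not a potency, so compound 2 and compound 3 could still separate at other doses or times.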